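The source may hold more compounds than are shown below. What is called first, only, known or untested is meant among the compounds shown, and "the series" means these compounds.

Measured compounds:
Compound 1, `O=C1NCCN1c1ccc(S(=O)(=O)Nc2cccc(Br)c2)cc1`: 76 nM
Compound 2, `COc1cccc(NS(=O)(=O)c2ccc(N3CCNC3=O)cc2)c1`: 200 nM

Compound 1 stands lowest of the two numbers in a functional assay on CHO-TAX 5-6 cells (Cricetulus griseus) for antiproliferative activity, read by sulforhodamine B assay, with a stated time of 48 h; a higher number here means a weaker inhibitor, a lower number a stronger inhibitor; its nearest neighbour is compound 2, reached by a 2.6-fold higher number from compound 1 to compound 2 (0.42 log units; beyond the scatter), a methoxy in place of bromo on an aromatic carbon. Compound 3, `Cc1cccc(NS(=O)(=O)c2ccc(N3CCNC3=O)cc2)c1`, is not yet measured and differs from compound 1 by methyl in place of bromo on an aromatic carbon. Within the data shown here, the one measured step bearing on it is the exchange of bromo for another small group at the same place, which gave a 2.6-fold higher number from compound 1 to compound 2 (0.42 log units; beyond the scatter); methyl is a different group from methoxy, so that step is only a rough guide. A step of similar or smaller size in the same direction is therefore expected, possibly no larger than the scatter. For compound 3 the estimated value is 120 nM, with a range from 50 nM to 300 nM. This corresponds to an expected step of a 1.6-fold higher number from compound 1 to compound 3 (0.20 log units; within the scatter).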

Compound 3, half-maximal inhibitory concentration: 150 nM
Compound 3: the middle estimate sits 1.3-fold (0.10 log units) below what was measured, within the range that was stated.
By their numbers in this assay, from the lowest: compounds 1, 3 and 2 (each within the scatter of the next, the first and the last beyond it).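

At this place, meta to a large group, the 3-bromophenyl to 3-methylphenyl exchange gives a 2.0-fold higher number from compound 1 to compound 3 (0.30 log units; within the scatter) in this assay and so leaves the number unresolved from that of the bromo compound. The methyl and methoxy compounds also cannot be told apart, with a 1.3-fold lower number from compound 2 to compound 3 (0.12 log units; within the scatter) here. Compound 3 therefore lies within the scatter of both earlier compounds, and the bromo-to-methoxy difference, the only one beyond the scatter among the three, does not divide this small set into two clear groups. On these data alone, whether an amine, a carboxylic acid or a longer chain at this place would stay within this narrow span remains open. No measurement shown here accounts for the small differences among these compounds.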